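Benzyl in place of 3-bromo-4-fluorophenyl on the amide

A few compounds are considered here, and "the series" means these few. Any claim that something is new, unique, unknown or untested is made for them only; others in the source may bear on it.

In a functional assay on MCF7 cells (Homo sapiens) for inhibition, read by MTT assay, with a stated time of 72 h (on this read-out higher numbers stand for weaker inhibition and lower numbers for stronger inhibition), compound 1 `CCc1ccc(NC(=O)C2CCN(C/C=C/c3ccccc3)CC2)cc1` gives 20000 nM and compound 2 `O=C(Nc1ccc(F)c(Br)c1)C1CCN(C/C=C/c2ccccc2)CC1` gives 13500 nM and the two stand level. Compound 3 `O=C(NCc1ccccc1)C1CCN(C/C=C/c2ccccc2)CC1` carries benzyl in place of 3-bromo-4-fluorophenyl on an amide-type nitrogen. Among the compounds with values here, only one measured step bears on this, an exchange on that same nitrogen (a 1.5-fold lower number from compound 1 to compound 2 (0.17 log units; within the scatter)), and it stayed within the scatter. Within the data shown here, no measured step covers benzyl. A change in this assay beyond the scatter is therefore not expected, in either direction. The expected step is small (a 1.1-fold higher number from compound 2 to compound 3 (0.05 log units; within the scatter)). For compound 3 the estimated value is 15000 nM (expected range 6000 nM to 40000 nM).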

Compound 3, half-maximal inhibitory concentration: > 100000 nM
Compound 3 gave a limit, no number (the forecaster's own chance of this, stated with the estimate: 15%); middle value at least 6.6-fold (0.82 log units) from the limit.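

In this assay, the exchange on the amide-type nitrogen now has a measurable effect: benzyl gives an at least 7.4-fold higher number from compound 2 to compound 3 (0.86 log units; beyond the scatter), and in place of 4-ethylphenyl it gives an at least 5.0-fold higher number from compound 1 to compound 3 (0.69 log units; beyond the scatter). Compound 3 gives a limit, not a number: the limit of > 100000 nM in this assay, at which 1 of the 3 values shown sits. One substituted phenyl in place of another left the number within the scatter, whereas benzyl moved it beyond the scatter.

The compounds shown leave open whether an unsubstituted phenyl on that nitrogen would stand with compound 1 and compound 2 or with compound 3. They also leave open where a longer chain, such as 2-phenylethyl, would fall.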